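A few compounds are considered here, and "the series" means these few. Any claim that something is new, unique, unknown or untested is made for them only; others in the source may bear on it.

Compound 1 `CC(C)C(c1ccc(-c2ccc3cccc(F)c3c2)[nH]c1=O)N1CCCCC1=O`: 6.4 nM
Compound 2 `CCn1ncc2c(F)cc(-c3ccc(C(CC)(CC)c4ncn(C)n4)c(=O)[nH]3)cc21`: 39 nM
Compound 3 `CCC(CC)(c1nnc[nH]1)c1ccc(-c2ccc3cc(F)cc(F)c3c2)[nH]c1=O`: 89 nM

These values come from an assay on CHO cells for displacement of a labelled ligand from prostaglandin E2 receptor EP3 subtype (Homo sapiens), read by radioligand binding; on this read-out lower numbers stand for stronger inhibition and higher numbers for weaker inhibition. Among the three, compound 1 has the lowest number; compound 2 is the nearest and compound 3 the furthest, and both of those gaps lie beyond the usual scatter. Compound 4 `CC(C)C(Cc1noc(=O)[nH]1)c1ccc(-c2ccc3cccc(F)c3c2)[nH]c1=O` has not yet been measured in this assay. It differs from compound 1 in one place: a group of 7 heavy atoms (3 carbon, 2 nitrogen, 2 oxygen; one five-membered aromatic ring with 3 hetero atoms) in place of a group of 7 heavy atoms (5 carbon, 1 nitrogen, 1 oxygen; one six-membered non-aromatic ring with 1 hetero atom), on a saturated chain carbon bound to an aromatic carbon and a saturated chain carbon. For the measured compounds named here, no pair of measured compounds shares this exact change, so the forecast rests only on the values shown. A modest weakening is expected, with the step from compound 1 to compound 4 estimated at a 2.3-fold higher number from compound 1 to compound 4 (0.37 log units; beyond the scatter). For compound 4 the expected result in this assay is 15 nM, with a likely range from 4 nM to 60 nM.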

Compound 4, inhibition constant: 34 nM
For compound 4 the middle estimate is 2.3-fold (0.36 log units) below the measured one; the measured number falls inside the stated range.
By their numbers in this assay, from the lowest: compound 1; then compounds 4 and 2 (each within the scatter of the next); then compound 3.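

In this assay, this saturated chain carbon now has its first one-place comparison, and swapping the 2-oxopiperidin-1-yl for the five-membered aromatic ring with 3 hetero atoms gives a 5.3-fold higher number from compound 1 to compound 4 (0.73 log units; beyond the scatter), a step beyond the scatter. The number therefore depends on which group sits here, even though both groups have the same heavy-atom count, yet compound 4 at 34 nM keeps binding in a measurable range. No measurement here bears on why the number rises.

The compounds shown leave open how a carboxylic acid or an amine would behave on this carbon. They also leave open whether the same swap would give a similar step on the cores of compound 2 or compound 3.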